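The compounds below may be only part of what the source reports. "The series", "measured", "known", "first", "only" and "open" are said of these compounds alone.

Going by the values given here, compound 2 `Cc1cccc2c1OCN(c1ccc3oc(-c4ccccc4)cc(=O)c3c1)C2` is one of only two compounds so far measured in a functional assay on MCF7 cells (Homo sapiens) for inhibition, read by MTT assay, with a stated time of 48 h; a higher number here means a weaker inhibitor, a lower number a stronger inhibitor. There compound 2 gives 14300 nM, while compound 1 `COc1cccc2c1OCN(c1ccc3oc(-c4ccccc4)cc(=O)c3c1)C2` gives 17000 nM; the two numbers stand within the scatter of each other, so no order can be read between them. Among the compounds with values here, the single measured step, a 1.2-fold lower number from compound 1 to compound 2 (0.08 log units; within the scatter), also exchanges a group on an aromatic carbon of the shared core and stays within the scatter. Compound 3 `O=c1cc(-c2ccccc2)oc2ccc(N3COc4c(cccc4[N+](=O)[O-])C3)cc12` differs from compound 2 by nitro in place of methyl on an aromatic carbon. Within the data shown here, no measured step exchanges methyl for nitro, so the only guidance is that the one substituent change seen at this carbon left the number within the scatter. The expected step is therefore small, a 1.0-fold lower number from compound 2 to compound 3 (0.01 log units; within the scatter), with no clear direction. The estimate for compound 3 in this assay is 14000 nM, with a range from 5000 nM to 40000 nM that is kept wide for lack of a matching precedent.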

Compound 3, half-maximal inhibitory concentration: 28400 nM
For compound 3 the middle estimate is 2.0-fold (0.31 log units) below the measured one; low and high end bracket the measured number.
By their numbers in this assay, from the lowest: compounds 2, 1 and 3 (each within the scatter of the next).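

In this assay, nitro in place of methyl on this aromatic carbon gives a 2.0-fold higher number from compound 2 to compound 3 (0.30 log units; within the scatter), and nitro in place of methoxy gives a 1.7-fold higher number from compound 1 to compound 3 (0.22 log units; within the scatter). Exchanging methyl or methoxy for nitro, which adds two hydrogen-bond acceptors to the count of methyl, therefore produces no step beyond the scatter at this carbon, so the three groups shown cannot be ranked here. No supporting evidence bears on these numbers.

The compounds shown leave open whether any group at this carbon would move the number beyond the scatter, for example an amine, a carboxylic acid or a longer alkyl chain. They also leave open whether changes elsewhere on the shared core, such as on its unfused phenyl ring, would do so.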